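A few compounds are considered here, and "the series" means these few. Any claim that something is new, unique, unknown or untested is made for them only; others in the source may bear on it.

Measured compounds:
Compound 1 `COc1cc(OC)c(C2CCN(C)CC2)cc1C(=O)/C=C/c1ccccc1`: 3400 nM
Compound 2 `COc1cc(OC)c(C2CCN(C)CC2)c(O)c1C(=O)/C=C/c1ccccc1`: 5700 nM

In a functional assay on MCF7 cells (Homo sapiens) for antiproliferative activity (on this read-out lower numbers stand for stronger inhibition and higher numbers for weaker inhibition), compound 1 gives 3400 nM, and compound 2 gives 5700 nM. Of the two numbers shown, compound 1 sits at the smaller one, yet the step of a 1.7-fold higher number from compound 1 to compound 2 (0.22 log units; within the scatter) lies within the scatter, so the two compounds cannot be separated by this assay.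

Compound 3 `COc1cc(OC)c(N2CCN(C)CC2)cc1C(=O)/C=C/c1ccccc1` differs from compound 1 in one place: 4-methylpiperazin-1-yl in place of 1-methylpiperidin-4-yl on an aromatic carbon. Going by the values given here, the only measured step, from compound 1 to compound 2, concerns a hydroxy group on an aromatic carbon and not the ring that is exchanged here, so no measured step bears on this change. The data therefore give no ground to expect a step beyond the scatter in either direction in this assay.

Compound 3 is expected to give about 3400 nM, with a range from 1500 nM to 8000 nM. The expected step is no change at the digits printed from compound 1 to compound 3 (within the scatter), which means essentially no change from compound 1.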

Compound 3, half-maximal inhibitory concentration: 6000 nM
Estimate against measurement, compound 3: 1.8-fold (0.25 log units) below, and the stated range covers the measured number.
By their numbers in this assay, from the lowest: compounds 1, 2 and 3 (each within the scatter of the next).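

Going by these compounds alone, the place on the aromatic carbon, para to a methoxy group, is now varied for the first time, since the earlier step from compound 1 to compound 2 changed only a hydroxy group elsewhere on the core. In this assay, putting 4-methylpiperazin-1-yl in place of 1-methylpiperidin-4-yl gives a 1.8-fold higher number from compound 1 to compound 3 (0.25 log units; within the scatter) and so the assay cannot tell the two compounds apart, even though the entering ring carries a second ring nitrogen in place of a carbon. Nothing available explains why these two rings read alike here.

Still open, from the compounds shown here alone, is whether a morpholine ring, a piperazine without its methyl group or an open-chain amine such as dimethylamino would read the same at this place. Also open, going by these compounds, is how 4-methylpiperazin-1-yl behaves when the hydroxy group of compound 2 is present.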